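The source may report more compounds than this note shows. Statements on the series, on what has been measured and on what is new or still open speak of the compounds shown alone.

Of the compounds shown here, three have been measured in an ADME assay on microsomes from liver (Rattus norvegicus, strain Wistar) for metabolic stability, tested at 2.5 uM; on this read-out higher numbers stand for fast clearance and lower numbers for slow clearance. Compound 1 `Fc1ccc(-c2ccc(Cn3nnc4ccccc43)cc2)c(F)c1` gives 6.4 mL/min/g, while compound 2 `Fc1cc(Cl)ccc1-c1ccc(Cn2nnc3ccccc32)cc1` gives 1.3 mL/min/g. The two differ by fluoro in place of chloro on an aromatic carbon, a change that made a step of a 4.9-fold higher number from compound 2 to compound 1 (0.69 log units; beyond the scatter). Compound 3 `Clc1cc(Br)c2nnn(CC3CC3)c2c1` gives 1.1 mL/min/g; the difference between its core and that of compound 2 is not broken down here. Compound 4 `Fc1cc(Br)c2nnn(CC3CC3)c2c1` has not yet been measured in this assay. It differs from compound 3 by fluoro in place of chloro on an aromatic carbon, the same kind of change as before, though here the place is meta to a bromo group, meta to a fused ring and para to a fused ring, rather than meta to a fluoro group and para to a large group. Because the earlier step of a 4.9-fold higher number from compound 2 to compound 1 (0.69 log units; beyond the scatter) was modest, compound 4 is expected to show a step of about a 3.2-fold higher number from compound 3 to compound 4 (0.50 log units; beyond the scatter). Compound 4 is therefore estimated at 3.5 mL/min/g, with a likely range from 1.5 mL/min/g to 8 mL/min/g.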

Compound 4, intrinsic clearance in a liver preparation (reported as CLH), per the amount of preparation that the assay uses: 0.5 mL/min/g
The estimate for compound 4 lay 7.0-fold (0.85 log units) above the measured number, outside the stated range (below it).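

In this assay, fluoro in place of chloro gives a 2.2-fold lower number from compound 3 to compound 4 (0.34 log units; beyond the scatter), so the same change moved the number in opposite directions on the two cores: the same change on two cores in this assay, a 4.9-fold higher number (0.69 log units; beyond the scatter) from compound 2 to compound 1 and a 2.2-fold lower number (0.34 log units; beyond the scatter) from compound 3 to compound 4, 11-fold (1.03 log units) apart, beyond the scatter of two such steps

The step seen on one core is therefore a poor guide to the step on the other in this series. These two pairs do not show why the cores differ, and they cannot say which part of either core matters or what the change would do on a third core.

From the compounds shown here alone, it remains open how a nitrile or a methoxy group would read in the same place on either core. Going by these compounds, it is also open whether an amine elsewhere on these cores would alter the step.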